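This account rests on a few compounds, and the source may have more. Where it says the series, first, only, none or still open, it means among the compounds named here.

Compound 2 `CC(C)C1(c2ccc(-c3ccc4ccccc4c3)[nH]c2=O)OC(=O)NC1=O` is the reference point. In a functional assay on U2OS cells for antagonist activity at prostaglandin E2 receptor EP3 subtype (Rattus norvegicus), read by FLIPR, with a stated time of 24 h (a higher number here means a weaker inhibitor, a lower number a stronger inhibitor), compound 2 gives 10 nM. Compound 1 `O=C1NC(=O)C(c2ccc(-c3ccc4ccccc4c3)[nH]c2=O)O1` gives 316 nM, so a 32-fold lower number from compound 1 to compound 2 (1.50 log units; beyond the scatter). Compound 3 `CC(C)C1(c2ccc(-c3ccc4c(ccn4C)c3)[nH]c2=O)OC(=O)NC1=O` gives 7.94 nM, a value that lies within the scatter of the number for compound 2. Compound 4 `CC(C)C1(c2ccc(-c3ccc4cccc(F)c4c3)[nH]c2=O)OC(=O)NC1=O` carries fluoro in place of hydrogen on an aromatic carbon. Going by the values given here, no measured step touches this part of the molecule: the single step seen concerns the isopropyl group on the saturated ring, and the change from compound 2 to compound 3 involves a different ring system, so neither bears directly on a fluorine on the aromatic carbon. Compound 4 is therefore expected to show no change at the digits printed from compound 2 to compound 4 (within the scatter), a step not beyond the scatter, with an estimated 10 nM between 3 nM and 32 nM.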

Compound 4, inhibition constant: 3.16 nM
Beside the measured number, compound 4's estimate is 3.2-fold (0.50 log units) above it; the measured number falls inside the stated range.
By their numbers in this assay, from the lowest: compound 4; then compounds 3 and 2 (each within the scatter of the next); then compound 1.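

In this assay, fluoro in place of hydrogen on an aromatic carbon gives a 3.2-fold lower number from compound 2 to compound 4 (0.50 log units; beyond the scatter), so this carbon, ortho to a fused ring and meta to a fused ring, accepts a substituent without loss of inhibition. Going by these compounds alone, the only earlier step concerned a saturated ring carbon; this one shows that a modest gain can also come from the aromatic part. No measurement shown here explains the change. From the compounds shown here alone, whether chloro, methoxy or an amine at this same carbon would lower the number further remains open, as does the effect of fluoro on the other aromatic carbons.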